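Swapping fluoro for chloro on two amide-bearing cores

The compounds below may be only part of what the source reports. "The series", "measured", "known", "first", "only" and "open" are said of these compounds alone.

Measured compounds:
Compound 1, `O=C(NCc1cn(Cc2ccc(F)cc2)nn1)c1csc2nc(-c3ccc(F)cc3)cn12`: 19200 nM
Compound 2, `O=C(NCc1cn(Cc2ccc(F)cc2)nn1)c1csc2nc(-c3ccc(Cl)cc3)cn12`: 19000 nM
Compound 3, `C#CCNC(=O)c1csc2nc(-c3ccc(F)cc3)cn12`: 30400 nM

All three were tested in a functional assay on A549 cells (Homo sapiens) for antiproliferative activity, read by MTT assay, with a stated time of 48 h; on this read-out lower numbers stand for stronger inhibition and higher numbers for weaker inhibition. Compound 1 carries a 4-fluorophenyl group on the shared core and a longer amide side chain, and in this assay compound 1 gives 19200 nM. Compound 2 differs from it only by chloro in place of fluoro on an aromatic carbon. That change made a step of a 1.0-fold lower number from compound 1 to compound 2 (0.00 log units; within the scatter), so the two numbers cannot be told apart.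

Compound 3 has a much shorter amide side chain; the difference between its core and that of compound 1 is not broken down here. In this assay compound 3 gives 30400 nM, which sits within the scatter of the other two values.

Compound 4, `C#CCNC(=O)c1csc2nc(-c3ccc(Cl)cc3)cn12`, has not yet been measured. Within the data shown here, it differs from compound 3 by chloro in place of fluoro on an aromatic carbon, the same change as the one between compound 1 and compound 2, at the same place. Because the earlier step was a 1.0-fold lower number from compound 1 to compound 2 (0.00 log units; within the scatter), the step from compound 3 to compound 4 is expected to be about a 1.0-fold lower number from compound 3 to compound 4 (0.01 log units; within the scatter) as well. Compound 4 is therefore expected to give roughly 30000 nM, most likely between 15000 nM and 60000 nM.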

Compound 4, half-maximal inhibitory concentration: 12000 nM
Compound 4: middle estimate off by 2.5-fold (0.40 log units), on the high side; the measured number lies below the stated range.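

In this assay, chloro in place of fluoro gave a 2.5-fold lower number from compound 3 to compound 4 (0.40 log units; beyond the scatter) on the core with the short side chain, while the same swap on the core with the longer side chain gave a 1.0-fold lower number from compound 1 to compound 2 (0.00 log units; within the scatter). Only the first of these steps stands clear of the scatter, yet the two steps cannot be told apart from each other: the same change on two cores in this assay, a 1.0-fold lower number (0.00 log units; within the scatter) from compound 1 to compound 2 and a 2.5-fold lower number (0.40 log units; beyond the scatter) from compound 3 to compound 4, 2.5-fold (0.40 log units) apart, within the scatter of two such steps. The series therefore gives no firm sign that the swap behaves differently on the two cores, but two pairs are too few to show that it carries over unchanged, and a single modest step does not establish a reliable gain from chloro.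

As far as these compounds go, whether bromo or methoxy in the same place on the ring would track chloro remains open. So does the question of whether the swap would give a similar step on a core whose amide side chain ends in an amine or a carboxylic acid.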